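A few compounds are considered here, and "the series" means these few. Any claim that something is new, unique, unknown or untested is made for them only; others in the source may bear on it.

Among the measured compounds shown here, compound 2, with the structure `O=C(/C=C(/C=C/c1ccc(O)cc1)NCCCO)/C=C/c1ccc(O)cc1`, is one of two compounds measured in a functional assay on HepG2 cells (Homo sapiens) for cytotoxicity, read by MTT assay, with a stated time of 48 h; on this read-out lower numbers stand for stronger inhibition and higher numbers for weaker inhibition. Its neighbour, compound 1, has the structure `COCCCNC(=C\C(=O)/C=C/c1ccc(O)cc1)/C=C/c1ccc(O)cc1`; in this assay compound 1 gives 61900 nM. In this assay compound 2 gives 54100 nM, the lowest of the two numbers, although the step of a 1.1-fold lower number from compound 1 to compound 2 (0.06 log units; within the scatter) means the two values cannot be ranked against each other.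

Compound 3, the unmeasured compound with the structure `O=C(/C=C(/C=C/c1ccc(O)cc1)NCCO)/C=C/c1ccc(O)cc1`, is reached from compound 2 by the change (hydroxy in place of hydroxymethyl on a saturated chain carbon, two bonds along the chain from an amine nitrogen).

For the measured compounds named here, only one measured step exists, a 1.1-fold lower number from compound 1 to compound 2 (0.06 log units; within the scatter), and it concerns a different part of the same chain, the change from methyl to hydrogen on its oxygen. Going by the values given here, that step did not move the number beyond the scatter, and no measured pair shows what exchanging 3-hydroxypropyl for 2-hydroxyethyl does. On this basis compound 3 is expected to show a step of a 1.0-fold higher number from compound 2 to compound 3 (0.01 log units; within the scatter), that is, no movement beyond the scatter. Compound 3 is therefore estimated at 55000 nM in this assay, with a range from 25000 nM to 120000 nM.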

Compound 3, half-maximal inhibitory concentration in the HepG2 assay: 48400 nM
Compound 3: the middle estimate sits 1.1-fold (0.06 log units) above what was measured; the range from low to high includes it.
By their numbers in the HepG2 assay, from the lowest: compounds 3, 2 and 1 (each within the scatter of the next).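

In the HepG2 assay the exchange leaves the reading unresolved: the result is a 1.1-fold lower number from compound 2 to compound 3 (0.05 log units; within the scatter), and with the methoxy-capped chain it is a 1.3-fold lower number from compound 1 to compound 3 (0.11 log units; within the scatter), so the three compounds cannot be ranked against one another. Among the compounds shown here, what the earlier compounds did not show is that this same change separates the two read-outs: in a physicochemical assay for solubility, using the shake flask method, in phosphate buffer, with a stated time of 90 min, at pH 6.8 (on this read-out higher numbers stand for higher solubility and lower numbers for lower solubility), compound 2 gives 137000 nM and compound 3 gives 38700 nM. Exchanging 3-hydroxypropyl for 2-hydroxyethyl therefore lowers solubility by a modest step beyond the scatter, while the numbers in the HepG2 assay stay within it: the measured solubility of compound 2, 137000 nM, and of compound 3, 38700 nM, a 3.5-fold lower number (0.55 log units; beyond the scatter)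

This rests on a single pair, so the compounds shown cannot tell whether solubility would keep following the length of the chain, and a longer chain carrying the same hydroxy group remains an open case. Also open, on these data alone, is what an amine or a carboxylic acid in place of that hydroxy group would do to the numbers in the HepG2 assay and in the physicochemical assay.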